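Methoxy on compound 2: working notes on cytotoxicity

This account rests on a few compounds, and the source may have more. Where it says the series, first, only, none or still open, it means among the compounds named here.

In an ADME assay on HMEC cells (Homo sapiens) for cytotoxicity, read by MTT assay (a lower number here means a stronger inhibitor, a higher number a weaker inhibitor), compound 1 (`Nc1ccccc1NC(=O)c1ccc(CNc2nc3cc(Cl)ccc3o2)cc1`) gives 17000 nM. In the same assay, compound 2 (`Nc1ccccc1NC(=O)c1ccc(CSc2nc3ccccc3[nH]2)cc1`) gives 14000 nM. Among the measured compounds shown here, these two values lie within the scatter of each other, so compound 2 stands level with compound 1 on the only numbers available. Compound 3 (`COc1ccc2nc(SCc3ccc(C(=O)Nc4ccccc4N)cc3)[nH]c2c1`) has methoxy in place of hydrogen on an aromatic carbon of compound 2 (methoxy in place of hydrogen on an aromatic carbon). For the measured compounds named here, no measured pair isolates a single change, so the data offer no direct precedent for this one. The expected result is a small step of a 1.2-fold lower number from compound 2 to compound 3 (0.07 log units; within the scatter), with no size beyond the scatter and no firm direction. This expectation is anchored on compound 2 at 14000 nM. The estimated value for compound 3 is 12000 nM, with an expected range of 6000 nM to 25000 nM.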

Compound 3, half-maximal inhibitory concentration: 10000 nM
Compound 3: middle estimate off by 1.2-fold (0.08 log units), on the high side; low and high end bracket the measured number.
By their numbers in this assay, from the lowest: compounds 3, 2 and 1 (each within the scatter of the next).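

Among the compounds shown here, this is the first pair that differs in one place: with methoxy in place of hydrogen on an aromatic carbon, this assay shows a 1.4-fold lower number from compound 2 to compound 3 (0.15 log units; within the scatter). The position therefore accepts methoxy, with its 2 heavy atoms, without a step beyond the scatter, and this single pair gives the change no firm direction. Nothing in hand gives a reason for this result.

On these data alone, whether this position stays as flat with an amine, a carboxylic acid or a longer chain remains open. Also open, as far as these compounds go, is whether methoxy gives a step of similar size on the core of compound 1, so this reading holds for one group on one core only.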